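Hydrazone swap on a shared core against maltase-glucoamylase

A few compounds are considered here, and "the series" means these few. Any claim that something is new, unique, unknown or untested is made for them only; others in the source may bear on it.

Measured compounds:
compound 1 `O=C(N/N=C/c1cccnc1)c1ccc(-c2nc3ccccc3s2)cc1`, "not active" (no number reported) in an assay on isolated protein for inhibition of Maltase-glucoamylase (Homo sapiens), with a stated time of 15 min; on this read-out lower numbers stand for stronger inhibition and higher numbers for weaker inhibition
compound 2 `O=C(N/N=C/c1cccc(O)c1O)c1ccc(-c2nc3ccccc3s2)cc1`, 11200 nM

Within the data shown here, compound 2 holds the only number obtained so far; in this assay compound 2 gives 11200 nM, while compound 1 is reported only as "not active" (no number reported), without a figure. Both share the same core and differ only in the ring hung on the carbon with a double bond to nitrogen.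

Compound 3 `COc1ccc(/C=N/NC(=O)c2ccc(-c3nc4ccccc4s3)cc2)cc1OC` has not yet been tested. Compared with compound 2 the change is 3,4-dimethoxyphenyl in place of 2,3-dihydroxyphenyl on a carbon with a double bond to nitrogen. Among the measured compounds shown here, nothing among the measured pairs shows how such a swap moves the read-out, so no measured step can be quoted. For the measured compounds named here, the only guide is that compound 1, which also lacks the hydroxyl groups of compound 2, showed no activity. On that basis a step toward weaker inhibition in this assay is expected, by about a 3.1-fold higher number from compound 2 to compound 3 (0.49 log units; beyond the scatter), beyond the usual scatter. Compound 3 is therefore expected to give about 35000 nM, within 10000 nM to 120000 nM.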

Compound 3, half-maximal inhibitory concentration: "not active" (no number reported)
Nothing numeric was reported for compound 3, and the estimate cannot be compared.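

Among these compounds, compound 3 is reported as "not active" (no number reported) and so, with no figure to set against compound 2, no step between the two can be read. No other information at hand explains this result. The compounds shown leave open how much weaker compound 3 is than compound 2, and whether the 2,3-dihydroxyphenyl group's hydrogen-bond donors matter.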